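The compounds below may be only part of what the source reports. "The series", "measured", "known", "first", "only" and "open" are said of these compounds alone.

The measured compounds and their values:

Compound 1 `NC(=O)c1nc(-c2ccccc2)n(-c2ccc(S(N)(=O)=O)cc2)n1` gives 52% in a functional assay on the whole organism for inhibition, with Rattus norvegicus as the target, read by paw edema, with stated times of 30 min and 3 h, at a dose of 0.28 mmol/kg by the oral route; on this read-out higher numbers stand for more inhibition at the one dose given (going by the name of the read-out) and lower numbers for less inhibition.

Compound 2 `NS(=O)(=O)c1ccc(-n2nc(C(=O)NC3CCCCC3)nc2-c2ccccc2)cc1` gives 65% in this assay.

Compound 2 stands highest of the two numbers in this assay; compound 1 is its nearest neighbour, and the gap between them, a number 13 percentage points higher from compound 1 to compound 2 (beyond the scatter), lies beyond the scatter. The unmeasured compound 3 `NNC(=O)c1nc(-c2ccccc2)n(-c2ccc(S(N)(=O)=O)cc2)n1` differs from compound 2 at the amide-type nitrogen whose other neighbour is the carbonyl carbon: amino in place of cyclohexyl on an amide-type nitrogen. Cut one bond further out, the difference reads cyclohexylcarbamoyl to aminocarbamoyl.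

Going by the values given here, only one measured step bears on this change. It is a number 13 percentage points higher from compound 1 to compound 2 (beyond the scatter), in which cyclohexyl entered in place of hydrogen on that same amide-type nitrogen. Compound 3 reverses that entry of cyclohexyl, and amino, with one heavy atom, is closer to hydrogen than to the six-carbon ring, so the step back is expected to be of about the same size in the opposite direction, a number 13 percentage points lower from compound 2 to compound 3 (beyond the scatter). Among the compounds with values here, no measured pair shows what amino itself does on this nitrogen, so the range is kept wide.

Compound 3 is therefore estimated at 52% in this assay, between 38% and 66%.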

Compound 3, a percentage reported as inhibition, in the whole organism at one dose (the size of the read-out at that dose, not a potency): 60%
Compound 3: the middle estimate sits 8 percentage points below what was measured; the range from low to high includes it.
By their numbers in this assay, from the lowest: compounds 1, 3 and 2 (each within the scatter of the next, the first and the last beyond it).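

In this assay, amino in place of cyclohexyl on the amide-type nitrogen gives a number 5 percentage points lower from compound 2 to compound 3 (within the scatter), while amino in place of hydrogen on the same nitrogen gives a number 8 percentage points higher from compound 1 to compound 3 (within the scatter). Compound 3 therefore cannot be separated from either of the other two compounds, even though they are set apart by a number 13 percentage points higher from compound 1 to compound 2 (beyond the scatter), so the three compounds no longer show a simple contrast between cyclohexyl and a bare amide hydrogen. Among these compounds, the six-membered carbon ring is not required for a reading within the scatter of compound 2, since amino, with no ring, gives such a reading, and no measurement at hand accounts for this result.

The compounds shown leave open how a methyl group, a longer chain such as n-butyl, or a phenyl ring would read on this nitrogen, and whether such groups would separate from the values seen here. Each value also gives the size of the read-out at one dose only, so the relative potency of these compounds remains open.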